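Quinazoline piperazine series: thiourea to urea on the ring nitrogen

The source may hold more compounds than are shown below. What is called first, only, known or untested is meant among the compounds shown, and "the series" means these compounds.

For the measured compounds named here, compound 2 `COc1cc2nc(N3CCN(/C(S)=N/c4ccccc4)CC3)nc(N)c2cc1OC` holds the lowest of the two numbers so far in an assay for binding affinity to Adrenergic receptor alpha-1 (Rattus norvegicus) (a higher number here means a weaker inhibitor, a lower number a stronger inhibitor), giving 0.00692 nM, while compound 1 `COc1cc2nc(N3CCN(C(=O)/C=C/C(=O)c4ccccc4)CC3)nc(N)c2cc1OC` gives 87.1 nM, a gap well beyond the scatter. Compound 3 `COc1cc2nc(N3CCN(C(=O)Nc4ccccc4)CC3)nc(N)c2cc1OC` has not been measured; it differs from compound 2 by a group of 9 heavy atoms (7 carbon, 1 nitrogen, 1 oxygen; one six-membered aromatic ring of carbon only) in place of a group of 9 heavy atoms (7 carbon, 1 nitrogen, 1 sulfur; one six-membered aromatic ring of carbon only), on an amine nitrogen in a ring. Going by the values given here, no measured pair shows this exchange, so only an expectation is possible: a modest loss in this assay seems likelier than a gain, with the step of a 4.3-fold higher number from compound 2 to compound 3 (0.64 log units; beyond the scatter) expected to exceed the scatter. Compound 3 is estimated at 0.03 nM, within a range of 0.002 nM to 0.5 nM.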

Compound 3, half-maximal inhibitory concentration: 27.5 nM
For compound 3 the middle estimate is 920-fold (2.96 log units) below the measured one; the whole stated range lies below it.
By their numbers in this assay, from the lowest: compound 2; then compound 3; then compound 1.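

In this assay, oxygen in place of sulfur on this amine nitrogen, with the rest of the group unchanged, gives a 4000-fold higher number from compound 2 to compound 3 (3.60 log units; beyond the scatter), so the sulfur-bearing group alone accounts for the very low number of compound 2. Anilino in place of 2-benzoylethenyl on the carbonyl carbon moves far less, with a 3.2-fold lower number from compound 1 to compound 3 (0.50 log units; beyond the scatter). Nothing measured here explains the size of either step.

Open, going by these compounds, is whether a methoxy group on the aromatic ring would keep the low number of compound 2. A longer chain in place of the aromatic ring is equally untested in these compounds.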